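This account rests on a few compounds, and the source may have more. Where it says the series, first, only, none or still open, it means among the compounds named here.

Compound 1 `O=C(O)CC(NC(=O)c1cccc(Br)c1)c1ccccc1` carries a bromine-bearing benzamide joined to a phenyl group, and compound 3 `O=C(O)CC(NC(=O)c1cccc(Br)c1)c1ccccc1F` differs from it by fluoro in place of hydrogen on an aromatic carbon. In a functional assay on MDA-MB-231 cells (Homo sapiens) for antiproliferative activity, read by MTT assay, with a stated time of 24 h (a higher number here means a weaker inhibitor, a lower number a stronger inhibitor), compound 1 gives only a limit, > 100000 nM. Compound 3 likewise gives a limit, > 100000 nM. The step from compound 1 to compound 3 is therefore a step that the two limits leave unreadable from compound 1 to compound 3, since both values sit at the limit of > 100000 nM in this assay, at which 2 of the 3 values shown sit.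

Compound 2 `O=C(O)CC(NC(=O)c1ccc(Cl)cc1Cl)c1ccccc1` has a different core; the difference between the two cores is not broken down here. In this assay, for the measured compounds named here, compound 2 gives 67200 nM, the only number in this set rather than a limit. Compound 4 `O=C(O)CC(NC(=O)c1ccc(Cl)cc1Cl)c1ccccc1F` is not yet measured; it differs from compound 2 by fluoro in place of hydrogen on an aromatic carbon, the same change as that from compound 1 to compound 3, made at the same place. Going by the values given here, because the one measured instance of this change reads a step that the two limits leave unreadable from compound 1 to compound 3, no size can be carried over from it, so the expectation leans on the weak activity seen across the set. Compound 4 is expected to stay near the value of its parent, with a step estimated as a 1.0-fold higher number from compound 2 to compound 4 (0.02 log units; within the scatter). Compound 4 is estimated at 70000 nM, most likely between 30000 nM and 150000 nM.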

Compound 4, half-maximal inhibitory concentration: 89300 nM
For compound 4 the middle estimate is 1.3-fold (0.11 log units) below the measured one; low and high end bracket the measured number.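

In this assay, the change from phenyl to 2-fluorophenyl gives a 1.3-fold higher number from compound 2 to compound 4 (0.12 log units; within the scatter), so on this core the two values cannot be told apart from the ordinary spread of repeated measurements. The same change on the core of compound 1 cannot be read, as the values on both sides of that step are limits of the assay and not numbers: the limit of > 100000 nM in this assay, at which 2 of the 4 values shown sit. This leaves one readable instance of the change, which shows no effect beyond the scatter on one core, but it does not show that the fluoro group is equally without effect on the other core, or that the two cores respond alike.

The compounds shown leave open what a methoxy group or an amine would do in the same place on the ring, where only hydrogen and fluoro appear here. They also leave open how the series would read with a methyl ester in place of the carboxylic acid, which all four compounds carry.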